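Swapping the aryl group for a dihydroxypropyl chain

The source may report more compounds than this note shows. Statements on the series, on what has been measured and on what is new or still open speak of the compounds shown alone.

Measured compounds and their values:
Compound 1 `O=[N+]([O-])c1ccc(-n2cc(CSc3nc4ccccc4s3)nn2)cc1` gives 65.5% in a functional assay on the whole organism (strain Albino Wistar) for inhibition, with Rattus norvegicus as the target, read by paw edema, with stated times of 1 h and 5 h, at a dose of 10 mg/kg by the oral route; a higher number here means more inhibition at the dose given (going by the name of the read-out), a lower number less inhibition.
Compound 2 `Cc1ccccc1-n1cc(CSc2nc3ccccc3s2)nn1` gives 43.4%.
Compound 3 `CCOc1ccc(-n2cc(CSc3nc4ccccc4s3)nn2)cc1` gives 34%.

Compound 2 holds the second highest number of the three. Its value and that of compound 3 sit within the scatter of each other, so no order between those two can be claimed; compound 1 lies above compound 2 by a gap beyond the scatter.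

Compound 4 `OCC(O)Cn1cc(CSc2nc3ccccc3s2)nn1` has not been measured. It differs from compound 2 in one place: 2,3-dihydroxypropyl in place of 2-methylphenyl on an aromatic nitrogen. Among the measured compounds shown here, the only step recorded between measured compounds is a number 31.5 percentage points lower from compound 1 to compound 3 (beyond the scatter), which concerns an exchange on an aromatic carbon, not the change of the whole group on the ring nitrogen, so it does not bear directly on the move to compound 4. For the measured compounds named here, no measured step tells what a 2,3-dihydroxypropyl in place of 2-methylphenyl does here. Without a guide, compound 4 is expected to land near or somewhat below compound 2, with a wide range.

The step from compound 2 to compound 4 is estimated as a number 8.4 percentage points lower from compound 2 to compound 4 (within the scatter). Compound 4 is therefore estimated at 35%, between 15% and 55%.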

Compound 4, a percentage reported as inhibition, in the whole organism at one dose (the size of the read-out at that dose, not a potency): 52.8%
Estimate against measurement, compound 4: 17.8 percentage points below; the range from low to high includes it.
By their numbers in this assay, from the lowest: compounds 3, 2 and 4 (each within the scatter of the next, the first and the last beyond it); then compound 1.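

Among the compounds shown here, at this position, on an aromatic nitrogen of the five-membered ring, the earlier compounds varied only the aryl group, so it was unknown whether a ring was needed there at all. In this assay, replacing 2-methylphenyl with 2,3-dihydroxypropyl gives a number 9.4 percentage points higher from compound 2 to compound 4 (within the scatter), so an open chain with no ring and with hydrogen-bond donors can stand in place of an aromatic ring carrying none, with no difference that can be told from the scatter. Nothing measured here explains why these two very different groups read alike.

A plain propyl chain would show whether the two hydroxyl groups matter, or whether the chain alone is enough. An amine, a carboxylic acid or a longer chain on the same nitrogen remains an open case, and a single dose says nothing about potency.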